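This account rests on a few compounds, and the source may have more. Where it says the series, first, only, none or still open, it means among the compounds named here.

Working notes on a small set of bromomethyl-substituted chromenones tested for growth inhibition.

Compound 1 `CCOc1ccc2c(=O)cc(CC)oc2c1CBr` is the parent with an ethoxy group and an ethyl chain. In a functional assay on KBVIN cells (Homo sapiens) for antiproliferative activity, read by sulforhodamine B assay, with a stated time of 72 h (on this read-out higher numbers stand for weaker inhibition of growth and lower numbers for stronger inhibition of growth), compound 1 returns only a limit, > 32100 nM, so its inhibition is not resolved. Compound 2 `CCc1cc(=O)c2ccc(OC(C)C)c(CBr)c2o1` carries the change methyl in place of hydrogen on a saturated chain carbon bound to an oxygen on an aromatic ring and a saturated chain carbon and in this assay compound 2 likewise returns only a limit, > 30700 nM. The step that the two limits leave unreadable from compound 1 to compound 2 therefore cannot be read, since both ends sit at a limit, the limit of > 32100 nM in this assay, at which 1 of the 3 values shown sits, and (the limit of > 30700 nM in this assay, at which 1 of the 3 values shown sits).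

Compound 3 `CCOc1ccc2c(=O)cc(C(C)Br)oc2c1CBr` differs from compound 1 by bromo in place of hydrogen on a saturated chain carbon bound to an aromatic carbon and a saturated chain carbon. In this assay, among the measured compounds shown here, compound 3 gives 12800 nM, the only resolved number in the set, and the step of an at least 2.5-fold lower number from compound 1 to compound 3 (0.39 log units; beyond the scatter) is the one readable gain.

Compound 4 `CC(C)Oc1ccc2c(=O)cc(C(C)Br)oc2c1CBr` is not yet measured. It differs from compound 3 by methyl in place of hydrogen on a saturated chain carbon bound to an oxygen on an aromatic ring and a saturated chain carbon, the same change as from compound 1 to compound 2, made at the same place. The cores of compound 3 and compound 4 differ from those of compound 1 and compound 2 only by bromo in place of hydrogen on a saturated chain carbon bound to an aromatic carbon and a saturated chain carbon. Because the earlier step that the two limits leave unreadable from compound 1 to compound 2 is unreadable, no size is established for this change, and the expectation for compound 4 rests mainly on compound 3 with 12800 nM as anchor.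

The step from compound 3 to compound 4 is expected to be a 1.2-fold higher number from compound 3 to compound 4 (0.07 log units; within the scatter). Compound 4 is estimated in this assay at 15000 nM, with a likely range from 6000 nM to 40000 nM, and a fair chance that only a limit is reported.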

Compound 4, concentration for 50% growth inhibition: 11400 nM
Compound 4: the middle estimate sits 1.3-fold (0.12 log units) above what was measured; the range from low to high includes it.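

In this assay, ethoxy to isopropoxy, read where both ends are numbers, is a 1.1-fold lower number from compound 3 to compound 4 (0.05 log units; within the scatter), and the same change on the other core cannot be read, as both of its ends are limits. Bromo in place of hydrogen on a saturated chain carbon bound to an aromatic carbon and a saturated chain carbon gives an at least 2.6-fold lower number from compound 2 to compound 4 (0.43 log units; beyond the scatter), so it points the same way on both cores: the same change on two cores in this assay, an at least 2.5-fold lower number (0.39 log units; beyond the scatter) from compound 1 to compound 3 and an at least 2.6-fold lower number (0.43 log units; beyond the scatter) from compound 2 to compound 4; the limit leaves it open whether they differ

Each of these two bromo steps starts from a limit and fixes no exact size, and a carry-over of the ethoxy to isopropoxy step from one core to the other is not shown, with only one of the two readable.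

The compounds shown leave open how this assay responds to a longer chain in place of ethoxy or isopropoxy, or to an amine in place of the added bromo on the saturated chain carbon. Also open, on these data alone, is how far the bromo step reaches on either core, and whether it differs between them.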